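Cyclic Nucleotide Analogues: A Halogen Swap on the Uracil Ring

The compounds below may be only part of what the source reports. "The series", "measured", "known", "first", "only" and "open" are said of these compounds alone.

Measured so far:
Compound 1 `O=c1[nH]c(=O)n([C@H]2C[C@@H]3O[PH](O)(O)OC[C@H]3O2)cc1F` gives 0.06 ug/mL in a functional assay on L1210 cells (Mus musculus) for antiproliferative activity; a higher number here means a weaker inhibitor, a lower number a stronger inhibitor.
Compound 2 `O=c1[nH]c(=O)n([C@H]2C[C@H](O)[C@@H](COP(=O)(O)O)O2)cc1C(F)(F)F` gives 0.017 ug/mL in this assay.
Compound 3 `O=c1[nH]c(=O)n([C@H]2C[C@@H]3O[PH](O)(O)OC[C@H]3O2)cc1Br` gives 457 ug/mL in this assay.

Compound 3 stands highest of the three numbers; compound 1 lies nearest and compound 2 furthest from it, both far lower. The step from compound 3 to compound 4 `O=c1[nH]c(=O)n([C@H]2C[C@@H]3O[PH](O)(O)OC[C@H]3O2)cc1Cl` is chloro in place of bromo on an aromatic carbon. Within the data shown here, the only measured step that bears on it is a 7600-fold higher number from compound 1 to compound 3 (3.88 log units; beyond the scatter), which shows that the halogen on this aromatic carbon matters greatly in this assay. Since chloro sits between fluoro and bromo, a lower number is expected for compound 4, though by how much is uncertain. Compound 4 is therefore estimated at 20 ug/mL, in the range 0.5 ug/mL to 200 ug/mL, a step of a 23-fold lower number from compound 3 to compound 4 (1.36 log units; beyond the scatter).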

Compound 4, concentration for 50% inhibition: 337 ug/mL
Compound 4: the middle estimate sits 17-fold (1.23 log units) below what was measured; measured number above the stated range.
By their numbers in this assay, from the lowest: compound 2; then compound 1; then compounds 4 and 3 (each within the scatter of the next).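

With a 1.4-fold lower number from compound 3 to compound 4 (0.13 log units; within the scatter) in this assay, chloro and bromo on this aromatic carbon cannot be told apart. The gap to fluoro is therefore not confined to bromo: a 5600-fold higher number from compound 1 to compound 4 (3.75 log units; beyond the scatter) shows that chloro also stands far from fluoro, so among these three halogens on the shared core, only compound 1 keeps a low number. Nothing measured here accounts for this divide.

As far as these compounds go, it remains open whether an amine or a methyl group on this carbon would track fluoro or the two heavier halogens. Also open, from the compounds shown here alone, is how trifluoromethyl, present in compound 2, would fare on the core of compound 1.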